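The source may report more compounds than this note shows. Statements on the series, on what has been measured and on what is new or still open speak of the compounds shown alone.

Measured compounds in an ADME assay on the whole organism with Oryza sativa as the target, tested at 10 uM; on this read-out higher numbers stand for a weaker effect at the one concentration tested and lower numbers for a stronger effect:
compound 1 `CCc1ccccc1NC(=O)N[C@@H](C)c1ccccc1`, 95%
compound 2 `C[C@H](NC(=O)Nc1ccccc1F)c1ccccc1`, 65%

Compound 2 holds the lowest of the two numbers; its nearest neighbour is compound 1, with a number 30 percentage points lower from compound 1 to compound 2 (beyond the scatter) separating them. Compound 3 `C[C@H](NC(=O)Nc1cc(F)ccc1F)c1ccccc1` is not yet measured. It differs from compound 2 by fluoro in place of hydrogen on an aromatic carbon. Within the data shown here, no measured step makes this same change; the only step seen, from compound 1 to compound 2, swaps one group for another rather than adding a second fluoro, so it gives no direct guide. On this basis the step of a number 5 percentage points lower from compound 2 to compound 3 (within the scatter) is expected to stay near the scatter. Compound 3 is estimated at 60%, within 40% to 80%.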

Compound 3, a percentage reported as activity, at one concentration (the size of the read-out at that concentration, not a potency): 99%
Compound 3: middle estimate off by 39 percentage points, on the low side, outside the stated range (above it).
By their numbers in this assay, from the lowest: compound 2; then compounds 1 and 3 (each within the scatter of the next).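

In this assay the added fluoro, para to a fluoro group and meta to a large group, gives a number 34 percentage points higher from compound 2 to compound 3 (beyond the scatter) and so moves towards a weaker effect at the one concentration tested. Among these compounds, this is the first measured addition to the ring of compound 2, and it shows that a further fluoro at this position does not extend the lower number of compound 2. Nothing available here bears on the reason for this step.

From the compounds shown here alone, whether the step belongs to fluoro itself or to this position remains open. A chloro or methoxy group on the same carbon would help separate the two.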